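This account rests on a few compounds, and the source may have more. Where it says the series, first, only, none or still open, it means among the compounds named here.

Working notes on the cytotoxicity series. In a toxicity assay (H9c2 cells) for cytotoxicity, with Rattus norvegicus as the target, read by neutral red uptake, with a stated time of 72 h (on this read-out lower numbers stand for stronger inhibition and higher numbers for weaker inhibition), compound 1 `C/C(=N\NC(=O)c1ccc(-c2ccccc2)cc1)c1ccccc1O` returns only an assay limit, > 100000 nM. Among the measured compounds shown here, compound 2 `C/C(=N\NC(=O)c1cnccn1)c1ccccc1O` gives the single numerical value in this assay, 41200 nM. The other entry, that of compound 1, is a limit (the limit of > 100000 nM in this assay, at which 1 of the 2 values shown sits). Compound 3 `C/C(=N\NC(=O)c1cccnc1)c1ccccc1O` differs from compound 2 by pyridin-3-yl in place of pyrazin-2-yl on a carbonyl carbon. No measured step of this kind is shown among the compounds; the change is expected to stay within the usual scatter, with an estimated step of a 1.0-fold lower number from compound 2 to compound 3 (0.01 log units; within the scatter). For compound 3 the estimate in this assay is 40000 nM, within a range of 15000 nM to 100000 nM.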

Compound 3, half-maximal inhibitory concentration: 6800 nM
Compound 3: the middle estimate sits 5.9-fold (0.77 log units) above what was measured; measured number outside the range, below it.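

In this assay, the group on the carbonyl carbon can clearly move the read-out: pyridin-3-yl in place of pyrazin-2-yl gives a 6.1-fold lower number from compound 2 to compound 3 (0.78 log units; beyond the scatter). The two groups have the same number of heavy atoms, and the entering ring has one hetero atom where the leaving ring has two. Nothing in the data at hand accounts for this step. Still open, from the compounds shown here alone, is whether a phenyl or pyridin-4-yl group at this place would read closer to compound 3 or compound 2. Going by these compounds, an amine on the pyridin-3-yl ring is equally open.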